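A Benzyl Urea in Place of an Aryl Amide

A few compounds are considered here, and "the series" means these few. Any claim that something is new, unique, unknown or untested is made for them only; others in the source may bear on it.

Compound 2 `CC(C)[C@@H](NC(=O)c1cccc(F)c1)C(=O)N1CCC(c2ccc(Cl)cc2)CC1` gives the lowest number of the two measured compounds in an assay on THP-1 cells for displacement of a labelled ligand from C-C chemokine receptor type 1 (Homo sapiens) (on this read-out higher numbers stand for weaker inhibition and lower numbers for stronger inhibition), with 24 nM. Compound 1 `CC(C)C(NC(=O)c1ccccc1)C(=O)N1CCN(c2ccc(Cl)cc2)CC1` gives 525 nM in this assay; these two compounds differ in more than one place, so only their two values can be set side by side, and the gap between them lies beyond the scatter. Compound 3 `CC(C)[C@@H](NC(=O)NCc1ccccc1)C(=O)N1CCC(c2ccc(Cl)cc2)CC1` has not yet been measured in this assay. It is built from compound 2 by a single change: benzylamino in place of 3-fluorophenyl on a carbonyl carbon. No step between measured compounds resembles this change, so nothing shown so far tells how large its effect should be. The expected step, a 2.5-fold higher number from compound 2 to compound 3 (0.40 log units; beyond the scatter), is modest and toward a higher number, or none beyond the scatter. Compound 3 is expected to give 60 nM in this assay, within 15 nM to 250 nM.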

Compound 3, half-maximal inhibitory concentration: 180 nM
Compound 3: middle estimate off by 3.0-fold (0.48 log units), on the low side, within the range that was stated.
By their numbers in this assay, from the lowest: compound 2; then compound 3; then compound 1.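

Among these compounds, this gives the first comparison at this position that differs in one place only: in this assay, benzylamino in place of 3-fluorophenyl on a carbonyl carbon gives a 7.5-fold higher number from compound 2 to compound 3 (0.88 log units; beyond the scatter). The position therefore responds to what stands on this carbonyl carbon, and this swap, which brings in a nitrogen and a hydrogen-bond donor that 3-fluorophenyl lacks, moves the number in the direction of weaker inhibition. No measurement shown explains the rise.

The change alters several things at once, so the compounds shown leave open whether the nitrogen, the extra carbon or the loss of fluorine accounts for the step. Phenylamino or 3-fluorobenzylamino on the same carbonyl carbon would begin to separate these, and a longer chain such as 2-phenylethylamino would show how far the ring can move from the carbonyl.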